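The source may hold more compounds than are shown below. What is called first, only, known or untested is meant among the compounds shown, and "the series" means these compounds.

Measured so far in a functional assay on MCF7 cells (Homo sapiens) for antiproliferative activity, read by MTT assay, with a stated time of 48 h; a lower number here means a stronger inhibitor, a higher number a weaker inhibitor
- compound 1 `Fc1ccc2[nH]c(-c3cn(-c4ccccc4)nc3-c3ccccc3)nc2c1` gives 2430 nM
- compound 2 `COc1ccc2[nH]c(-c3cn(-c4ccccc4)nc3-c3ccccc3)nc2c1` gives 1590 nM
- compound 3 `FC(F)(F)c1ccc2[nH]c(-c3cn(-c4ccccc4)nc3-c3ccccc3)nc2c1` gives 2660 nM

Compound 1 lies within the scatter of both other compounds, so the three values give no usable order in this assay.

Compound 4 `Fc1ccc2[nH]c(-c3cn(-c4ccccc4)nc3-c3ccc(Cl)cc3)nc2c1` is compound 1 with one change, phenyl to 4-chlorophenyl: chloro in place of hydrogen on an aromatic carbon. The chloro sits on an aromatic carbon of a six-membered aromatic ring of carbon only, para to a large group.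

Within the data shown here, no measured step makes this change. The nearest evidence is three substituent swaps made elsewhere on the shared core: a 1.5-fold lower number from compound 1 to compound 2 (0.18 log units; within the scatter), a 1.1-fold higher number from compound 1 to compound 3 (0.04 log units; within the scatter) and a 1.7-fold higher number from compound 2 to compound 3 (0.22 log units; within the scatter). All three stay within the scatter, which shows a flat response at that one place but says little about the new site. A step beyond the scatter is therefore not expected, and no firm direction can be assigned.

For compound 4 the expected value is 2100 nM, with an estimated range from 900 nM to 4800 nM. This estimate means an expected 1.2-fold lower number from compound 1 to compound 4 (0.06 log units; within the scatter).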

Compound 4, half-maximal inhibitory concentration: 2830 nM
Beside the measured number, compound 4's estimate is 1.3-fold (0.13 log units) below it; the range from low to high includes it.
By their numbers in this assay, from the lowest: compounds 2, 1, 3 and 4 (each within the scatter of the next).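

In this assay, chloro in place of hydrogen on an aromatic carbon gives a 1.2-fold higher number from compound 1 to compound 4 (0.07 log units; within the scatter), and this is the only step shown at this position. Phenyl to 4-chlorophenyl therefore leaves the number within the scatter, so the flat response seen among compound 1, compound 2 and compound 3 at another place on the shared core now has a counterpart at a second place. Nothing shown gives a reason for this flat response.

A single chloro does not define the tolerance of this position: an amine, a carboxylic acid or a longer chain in place of the chloro could still give a step beyond the scatter. Also open, as far as these compounds go, is whether chloro would give a similar step on compound 2, with methoxy in place of fluoro.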